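Pyridine nitrogen moved across the ring in compound 3

This account rests on a few compounds, and the source may have more. Where it says the series, first, only, none or still open, it means among the compounds named here.

Among the measured compounds shown here, compound 2 `Oc1ccc(-c2cc(-c3ccc(Cl)cc3)nc(-c3ccccn3)c2)cc1` is the weaker of the two compounds measured so far: in an assay on isolated protein for inhibition of DNA topoisomerase 1 (Homo sapiens), with a stated time of 30 min, tested at 100 uM (a lower number here means a weaker effect, a higher number a stronger effect of the compound at the concentration tested), compound 2 gives 12.7%, while compound 1 `Oc1ccc(-c2cc(-c3ccc(Cl)cc3)nc(-c3cccs3)c2)cc1` gives 38.8%. For the measured compounds named here, the only step seen so far, a number 26.1 percentage points lower from compound 1 to compound 2 (beyond the scatter), exchanges a thiophen-2-yl for a pyridin-2-yl. Compound 2 stands lowest of the two.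

Compound 3 `Oc1ccc(-c2cc(-c3ccncc3)nc(-c3ccc(Cl)cc3)c2)cc1` differs from compound 2 in one place: pyridin-4-yl in place of pyridin-2-yl on an aromatic carbon. Going by the values given here, no measured step involves a pyridin-4-yl, so the step from the pyridin-2-yl to it has no direct precedent; the single known step concerns a different exchange at the same place. With nothing more to lean on, the inhibition of compound 3 is expected to stay near that of compound 2, and the estimated step of a number 2.3 percentage points higher from compound 2 to compound 3 (within the scatter) is not expected to go beyond the scatter. Compound 3 is therefore estimated at 15%, within a range of 0% to 35%.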

Compound 3, a percentage reported as inhibition, at one concentration (the size of the read-out at that concentration, not a potency): 5.9%
Estimate against measurement, compound 3: 9.1 percentage points above; the measured number falls inside the stated range.
By their numbers in this assay, from the lowest: compounds 3 and 2 (each within the scatter of the next); then compound 1.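

In this assay, shifting the ring nitrogen from pyridin-2-yl to pyridin-4-yl at this position gives a number 6.8 percentage points lower from compound 2 to compound 3 (within the scatter) and so does not separate the two pyridines. The exchange of thiophen-2-yl for pyridin-4-yl gives a number 32.9 percentage points lower from compound 1 to compound 3 (beyond the scatter) and shows that the lower number seen earlier with pyridin-2-yl also holds for a second pyridine, so at this position the gap lies between thiophen-2-yl and both pyridines, whichever way the nitrogen is placed. Nothing on hand accounts for that gap.

As far as these compounds go, what a phenyl, a furan-2-yl or an open-chain amine would give at this position remains open. Also open, from the compounds shown here alone, is whether a number above that of compound 1 can be reached at this position at all.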